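Carbamoylpropyl for carbamoyl-hydroxyethyl on the benzyloxybenzylamine

A few compounds are considered here, and "the series" means these few. Any claim that something is new, unique, unknown or untested is made for them only; others in the source may bear on it.

Two compounds carry numbers in a functional assay on the whole organism with Mus musculus as the target (on this read-out lower numbers stand for an effect already at smaller amounts and higher numbers for an effect only at larger amounts of compound), so far. Compound 1 `NC(=O)CNCc1ccccc1` gives 490 mg/kg in this assay. Compound 2 `NC(=O)[C@@H](CO)NCc1ccc(OCc2ccccc2)cc1` gives 133 mg/kg in this assay, the lowest of the two numbers, a gap to compound 1 that lies beyond the scatter. Compound 3 `CC[C@H](NCc1ccc(OCc2ccccc2)cc1)C(N)=O` is not yet measured; its change from compound 2 is 1-carbamoylpropyl in place of 1-carbamoyl-2-hydroxyethyl on an amine nitrogen. Within the data shown here, with no measured step of this kind available, only a small step, if any, is expected: the estimated step of a 1.2-fold lower number from compound 2 to compound 3 (0.08 log units; within the scatter) stays near the scatter. Compound 3 is expected to give about 110 mg/kg in this assay, between 50 mg/kg and 250 mg/kg.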

Compound 3, dose for half-maximal effect: 119 mg/kg
Compound 3: the middle estimate sits 1.1-fold (0.03 log units) below what was measured; measured number inside the range.
By their numbers in this assay, from the lowest: compounds 3 and 2 (each within the scatter of the next); then compound 1.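

On the amine nitrogen, 1-carbamoylpropyl in place of 1-carbamoyl-2-hydroxyethyl gives in this assay a 1.1-fold lower number from compound 2 to compound 3 (0.05 log units; within the scatter) and so leaves the number unchanged within the scatter. At this position, the hydroxy group of the side chain is therefore not required for the effect on this read-out, even with one hydrogen-bond donor and one hydrogen-bond acceptor fewer. No measurement at hand gives a reason for this result.

Still open, as far as these compounds go, is whether a longer chain, or a carboxylic acid in place of the carbamoyl group, would hold this level. From the compounds shown here alone, the other configuration at the defined stereocentre also remains open.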